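The source may report more compounds than this note shows. Statements on the series, on what has been measured and on what is new or still open speak of the compounds shown alone.

Measured compounds in a functional assay on PC-3 cells (Homo sapiens) for cytotoxicity, read by MTT assay; a lower number here means a stronger inhibitor, a higher number a weaker inhibitor:

compound 1 `Cc1nc(Nc2ccccc2)sc1C(=O)/C=C/c1ccc(Cl)cc1` — > 25000 nM
compound 2 `Cc1ccc(Nc2nc(C)c(C(=O)/C=C/c3ccc(Cl)cc3)s2)cc1` — > 25000 nM

Compound 1 stands nowhere on a numerical scale: its value in this assay, > 25000 nM, is a limit of the assay and not a number. Compound 2 likewise gives only > 25000 nM, again a limit. Among the measured compounds shown here, the one measured step, a step that the two limits leave unreadable from compound 1 to compound 2, cannot be read in size or direction because of the limit of > 25000 nM in this assay, at which 2 of the 2 values shown sit. For the measured compounds named here, no second assay and no further compound add any readable step.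

Compound 3 `Cc1nc(Nc2ccccc2)sc1C(=O)/C=C/c1ccccc1` is not yet measured. It differs from compound 1 by hydrogen in place of chloro on an aromatic carbon. Going by the values given here, no measured step bears on this change: the only step in hand concerns a methyl on the aniline ring, not the chloro on the cinnamoyl ring, and even that step is unreadable. There is therefore no basis for expecting a step beyond the scatter in either direction; the most that can be said is that both measured compounds sit at the limit, and compound 3 is expected to do the same, with a step that the limit leaves unreadable from compound 1 to compound 3 that is effectively nil. Compound 3 is estimated at 40000 nM (range 15000 nM to 150000 nM), most probably reported again only as a limit.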

Compound 3, half-maximal inhibitory concentration: > 25000 nM
Compound 3 ended at the assay's limit; the forecaster's own chance of this, stated with the estimate: 85%; the middle value does not contradict the limit.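

Compound 3 gives > 25000 nM in this assay, a limit and not a number. The step from compound 1 to compound 3 cannot be read, because all values sit at one limit: the limit of > 25000 nM in this assay, at which 3 of the 3 values shown sit.

The compounds shown leave open whether the change from 4-chlorophenyl to phenyl alters the result in this assay in either direction.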